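The source may report more compounds than this note shows. Statements on the series, on what has been measured and on what is new or still open speak of the compounds shown alone.

In a functional assay on MOLT-4 cells (Homo sapiens) (on this read-out lower numbers stand for stronger inhibition and higher numbers for weaker inhibition), compound 1 `Nc1ncnc2c1ncn2C[C@@H]1C[C@H](CO)c2ccccc21` gives 24 ug/mL and compound 2 `OC[C@H]1C[C@@H](Cn2cnc3c(Cl)ncnc32)c2ccccc21` gives 24 ug/mL as its value, which places compound 2 level with compound 1 at the digits available. The next structure is compound 3 `COc1ncnc2c1ncn2C[C@@H]1C[C@H](CO)c2ccccc21`, which has methoxy in place of chloro on an aromatic carbon and is otherwise the same as compound 2. The counted difference is methoxy in place of chloro on an aromatic carbon as computed from the two structures. The change sits on the same aromatic carbon that separates compound 1 from compound 2. Within the data shown here, that is the only measured step bearing on it: chloro in place of amino on an aromatic carbon, reading no change at the digits printed from compound 1 to compound 2 (within the scatter) in this series. Among the measured compounds shown here, no methoxy compound has yet been measured on this core, so the evidence is thin and neither direction can be favoured. With compound 2 at 24 ug/mL as the starting point, no shift beyond the scatter is expected in this assay for this exchange. The expected change is no change at the digits printed from compound 2 to compound 3 (within the scatter) on this estimate. For compound 3 the estimate is 24 ug/mL with an expected range of 11 ug/mL to 50 ug/mL in this read-out.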

Compound 3, half-maximal inhibitory concentration: 24 ug/mL
The estimate for compound 3 equals the measured number at the digits printed; the range from low to high includes it.
By their numbers in this assay, from the lowest: compounds 1, 2 and 3 (each within the scatter of the next).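

Working notes on the aromatic carbon of the shared core, read in this assay: the methoxy exchange gives no change at the digits printed from compound 2 to compound 3 (within the scatter), and the direct comparison gives no change at the digits printed from compound 1 to compound 3 (within the scatter), so amino, chloro and methoxy now all stand at this carbon without separation, where the earlier pair covered only two groups. The flat reading now extends to a group that enters with more heavy atoms than chloro and with a hydrogen-bond acceptor where chloro has none, so neither counted difference separates compound 2 and compound 3 on this read-out. No evidence on hand accounts for this flat reading.

The compounds shown leave open whether a longer chain on the oxygen, such as butoxy, or a dimethylamino or benzylamino group at this same carbon would move the value beyond the scatter. They also leave open whether the shared core responds to change elsewhere, for instance a carboxylic acid in place of the hydroxymethyl group, since every step shown falls at this one carbon.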